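Predicting a trihydroxyphenyl swap on a shorter-chain hydrazone

The source may report more compounds than this note shows. Statements on the series, on what has been measured and on what is new or still open speak of the compounds shown alone.

Measured so far:
compound 1, `O=C(CCCc1nc2ccccc2c(=O)[nH]1)N/N=C/c1cc(O)c(O)c(O)c1`, 40000000 nM;
compound 2, `COc1ccc(/C=N/NC(=O)CCCc2nc3ccccc3c(=O)[nH]2)cc1`, 180000000 nM;
compound 3, `COc1ccc(/C=N/NC(=O)CCc2nc3ccccc3c(=O)[nH]2)cc1`, 75000000 nM.

All three were tested in a physicochemical assay, read by spectrophotometry, with a stated time of 6 min; a higher number here means a weaker inhibitor, a lower number a stronger inhibitor. Compound 2 and compound 1 share a core and differ in one place: 3,4,5-trihydroxyphenyl in place of 4-methoxyphenyl on a carbon with a double bond to nitrogen. That change gave a 4.5-fold lower number from compound 2 to compound 1 (0.65 log units; beyond the scatter). Compound 3 carries a core that differs from that of compound 2, and the difference between the two cores is not broken down here. Compound 3 and compound 1 give numbers within the usual scatter of each other.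

Compound 4, `O=C(CCc1nc2ccccc2c(=O)[nH]1)N/N=C/c1cc(O)c(O)c(O)c1`, is not yet measured. It differs from compound 3 by the same change: 3,4,5-trihydroxyphenyl in place of 4-methoxyphenyl on a carbon with a double bond to nitrogen. Because the earlier step was a 4.5-fold lower number from compound 2 to compound 1 (0.65 log units; beyond the scatter), a step of similar size is expected here, a 4.2-fold lower number from compound 3 to compound 4 (0.62 log units; beyond the scatter). Compound 4 is therefore estimated at 18000000 nM, expected between 6000000 nM and 50000000 nM.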

Compound 4, half-maximal inhibitory concentration: 35000000 nM
The estimate for compound 4 lay 1.9-fold (0.29 log units) below the measured number; the range from low to high includes it.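

In this assay, placing 3,4,5-trihydroxyphenyl instead of 4-methoxyphenyl on the carbon with a double bond to nitrogen gave a 2.1-fold lower number from compound 3 to compound 4 (0.33 log units; beyond the scatter), the same direction as a 4.5-fold lower number from compound 2 to compound 1 (0.65 log units; beyond the scatter), so the change gave a stronger inhibitor on both cores. Two pairs show only that the direction carried over; they cannot set a rule for other cores or show how reliably the size of the step carries over. Nothing here explains why the change lowers the number on either core.

The compounds shown leave open how an amine or a carboxylic acid would compare in place of the 3,4,5-trihydroxyphenyl group. They also leave open whether the change would carry over to a core with a longer chain.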